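The compounds below may be only part of what the source reports. "The series", "measured", "known", "first", "only" and "open" are said of these compounds alone.

Measured in an assay on LtK cells with ATP-sensitive inward rectifier potassium channel 11 (Homo sapiens) as the target; on this read-out lower numbers stand for an effect already at smaller amounts and higher numbers for an effect only at larger amounts of compound:
Compound 1, `CCCC(C)C(=O)Nc1c(C(O)(C(F)(F)F)C(F)(F)F)ccc2ccccc12` — > 10000 nM, a limit of the assay.
Compound 2, `O=C(Nc1c(C(O)(C(F)(F)F)C(F)(F)F)ccc2ccccc12)c1ccc(I)cc1` — 154 nM.
Compound 3, `O=C(Nc1c(C(O)(C(F)(F)F)C(F)(F)F)ccc2ccccc12)c1ccc(OC(F)(F)F)cc1` — > 10000 nM, a limit of the assay.

Compound 3 thus stands at the limit of > 10000 nM in this assay, at which 2 of the 3 values shown sit, and no number is known for it. Compound 4, `O=C(Nc1c(C(O)(C(F)(F)F)C(F)(F)F)ccc2ccccc12)c1ccc(Cl)c(Cl)c1`, differs from compound 3 by 3,4-dichlorophenyl in place of 4-(trifluoromethoxy)phenyl on a carbonyl carbon. Among the measured compounds shown here, the one readable step at this carbonyl carbon is an at least 64-fold higher number from compound 2 to compound 3 (1.81 log units; beyond the scatter), while a step that the two limits leave unreadable from compound 1 to compound 3 stays unreadable. Since compound 2 carries a halogenated phenyl on the same carbonyl carbon and gives 154 nM in this assay, a return toward that value is expected, and compound 4 is estimated to show an at least 33-fold lower number from compound 3 to compound 4 (1.52 log units; beyond the scatter). Compound 4 is therefore expected to give 300 nM, within a range of 60 nM to 5000 nM.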

Compound 4, half-maximal effective concentration: 194 nM
Estimate against measurement, compound 4: 1.5-fold (0.19 log units) above; the measured number falls inside the stated range.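

In this assay, 3,4-dichlorophenyl on the carbonyl carbon brings a large step against 4-(trifluoromethoxy)phenyl (an at least 51-fold lower number from compound 3 to compound 4 (1.71 log units; beyond the scatter)) and against 1-methylbutyl (an at least 51-fold lower number from compound 1 to compound 4 (1.71 log units; beyond the scatter)). Against 4-iodophenyl it shows no separation (a 1.3-fold higher number from compound 2 to compound 4 (0.10 log units; within the scatter)), so two differently halogenated phenyl groups stand level here, while compound 3, also a substituted phenyl, shows that a phenyl alone does not suffice. Compound 1 and compound 3 are limits of the assay, not numbers: the limit of > 10000 nM in this assay, at which 2 of the 4 values shown sit.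

Open, from the compounds shown here alone, is whether the halogens themselves matter or only their place on the phenyl. Also open, going by these compounds, is where a plain phenyl, or a phenyl carrying an amine or a carboxylic acid, would fall.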